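This account rests on a few compounds, and the source may have more. Where it says the series, first, only, none or still open, it means among the compounds named here.

Measured compounds in a functional assay on MCF7 cells (Homo sapiens) for antiproliferative activity, read by MTT assay, with a stated time of 72 h; a lower number here means a stronger inhibitor, a higher number a weaker inhibitor:
compound 1 `O=C(COc1ccc(C(=O)/C=C/c2ccc(Cl)cc2Cl)cc1)N[C@H]1CCOC1=O` gives 34400 nM
compound 2 `O=C(COc1ccc(C(=O)/C=C/c2ccc(F)c(F)c2)cc1)N[C@H]1CCOC1=O` gives > 64000 nM, a limit of the assay
compound 3 `O=C(COc1ccc(C(=O)/C=C/c2ccc(F)cc2)cc1)N[C@H]1CCOC1=O` gives > 64000 nM, a limit of the assay

Compound 3 thus sits at the limit of this assay, and the limit of > 64000 nM in this assay, at which 2 of the 3 values shown sit, shows it is not alone there. Only compound 1 returns a number, and the step of an at least 1.8-fold higher number from compound 1 to compound 3 (0.26 log units; that floor lies within the scatter) is read against that limit. The step that the two limits leave unreadable from compound 2 to compound 3 cannot be sized at all.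

Compound 4 `CC(C)c1ccc(/C=C/C(=O)c2ccc(OCC(=O)N[C@H]3CCOC3=O)cc2)cc1` differs from compound 3 by isopropyl in place of fluoro on an aromatic carbon. Going by the values given here, no measured step swaps a halogen for an isopropyl group on that ring; the three steps among compounds 1, 2 and 3 exchange halogens only, and two of them end at the limit. There is therefore no measured guide for the direction of this change, and the expectation for compound 4 can only be that it stays near the limit, so the step that the limit leaves unreadable from compound 3 to compound 4 is expected to lie within the scatter. Compound 4 is estimated at 70000 nM, with a range from 25000 nM to 200000 nM.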

Compound 4, half-maximal inhibitory concentration: 23400 nM
Beside the measured number, compound 4's estimate is 3.0-fold (0.48 log units) above it, and the stated range ends above it.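

In this assay, isopropyl at this place, para to a large group, gives a measured number where fluoro gave only a limit, with an at least 2.7-fold lower number from compound 3 to compound 4 (0.43 log units; beyond the scatter). The 4-isopropylphenyl ring reads the same way against the 3,4-difluorophenyl ring, with an at least 2.7-fold lower number from compound 2 to compound 4 (0.43 log units; beyond the scatter). Against the 2,4-dichlorophenyl ring there is a 1.5-fold lower number from compound 1 to compound 4 (0.17 log units; within the scatter), so these two rings cannot be told apart here, and compound 4 shows that a measurable number on this ring does not require a halogen.

Compound 2 and compound 3 still mark only a limit, so the difference between them stays unreadable: the limit of > 64000 nM in this assay, at which 2 of the 4 values shown sit. The compounds shown also leave open how other groups at this place, such as a methyl, a tert-butyl or a dimethylamino group, would read.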